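The source may report more compounds than this note shows. Statements on the series, on what has been measured and on what is new or still open speak of the compounds shown alone.

Compound 2 `CC(C)n1nc(-c2cc(C(C)(C)C)on2)c2c(N)ncnc21` gives 2100 nM in an assay on isolated protein for inhibition of proto-oncogene tyrosine-protein kinase receptor Ret variant V804M (Homo sapiens), read by radiometric assay and 33P incorporation, in the presence of a further agent that is not named here (a higher number here means a weaker inhibitor, a lower number a stronger inhibitor), the higher of the two numbers at hand; its nearest neighbour is compound 1 `CC(C)n1nc(-c2ccon2)c2c(N)ncnc21`, and in this assay compound 1 gives 903 nM. For the measured compounds named here, the only step among the measured compounds is a 2.3-fold higher number from compound 1 to compound 2 (0.37 log units; beyond the scatter), and it is the one that bears on what follows. Compound 3 `CC(C)c1cc(-c2nn(C(C)C)c3ncnc(N)c23)no1` differs from compound 2 by hydrogen in place of methyl on a saturated chain carbon bound to an aromatic carbon and two saturated chain carbons. This change takes back part of the step that separated compound 1 from compound 2, so a somewhat lower number for compound 3 is expected in this assay, an expected 1.4-fold lower number from compound 2 to compound 3 (0.15 log units; within the scatter), smaller than the step from compound 1 to compound 2 and possibly within the scatter. Compound 3 is therefore estimated at 1500 nM in this assay, with a range from 700 nM to 3500 nM.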

Compound 3, half-maximal inhibitory concentration: 355 nM
Estimate against measurement, compound 3: 4.2-fold (0.63 log units) above, and the stated range ends above it.
By their numbers in this assay, from the lowest: compound 3; then compound 1; then compound 2.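

At this aromatic carbon, the outcome in this assay depends on which alkyl group is present, not simply on whether one is present: isopropyl in place of hydrogen gives (a 2.5-fold lower number from compound 1 to compound 3 (0.41 log units; beyond the scatter)), whereas tert-butyl in place of hydrogen gives (a 2.3-fold higher number from compound 1 to compound 2 (0.37 log units; beyond the scatter)), in the opposite direction. The loss of a single methyl, which turns tert-butyl into isopropyl, gives (a 5.9-fold lower number from compound 2 to compound 3 (0.77 log units; beyond the scatter)), the largest step among these compounds, so this one carbon separates the weakest compound here from the strongest. No measurement at hand explains this reversal.

The compounds shown leave open whether an ethyl or cyclopropyl group on this aromatic carbon would fall nearer to isopropyl or to hydrogen. They also leave open how an amine or a carboxylic acid would fare there.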